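One group changes on compound 3

The source may hold more compounds than are shown below. What is called first, only, known or untested is meant among the compounds shown, and "the series" means these compounds.

Values in an ADME assay on HEK293 cells (Homo sapiens) for cytotoxicity, read by luminescence, with a stated time of 72 h (a lower number here means that less compound is needed, a higher number that more compound is needed for the effect), each one a limit and not a number:
- Compound 1 `CCOC(=O)c1c(-c2cccc(-c3ccccc3)c2)[nH]c2cc(OC)c(F)cc2c1=O`: > 22000 nM
- Compound 2 `CCOC(=O)c1c(-c2cccc(OC)c2)[nH]c2cc(OC)c(F)cc2c1=O`: > 22000 nM
- Compound 3 `CCOC(=O)c1c(-c2cccc(-c3c(C)cccc3C)c2)[nH]c2cc(OC)c(F)cc2c1=O`: > 22000 nM

Compound 3 has no exact number and stands with the other two compounds at the limit of > 22000 nM in this assay, at which 3 of the 3 values shown sit. Compound 4 `CCOC(=O)c1c(-c2cccc(-c3ccccc3Cl)c2)[nH]c2cc(OC)c(F)cc2c1=O` carries 2-chlorophenyl in place of 2,6-dimethylphenyl, on an aromatic carbon of a six-membered aromatic ring of carbon only, meta to a large group (2-chlorophenyl in place of 2,6-dimethylphenyl on an aromatic carbon). The measured steps that bear on this change are a step that the two limits leave unreadable from compound 1 to compound 3, a step that the two limits leave unreadable from compound 2 to compound 3 and a step that the two limits leave unreadable from compound 1 to compound 2, so none of them has a readable size. All three compounds nonetheless sit at the same limit, so no step beyond the scatter is expected in this assay. The expected step is a step that the limit leaves unreadable from compound 3 to compound 4, with no clear direction. For compound 4 the estimated value is 25000 nM, within an expected range from 12000 nM to 50000 nM.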

Compound 4, half-maximal effective concentration: > 22000 nM
Compound 4: no number, only a limit; the forecaster's own chance of this, stated with the estimate: 85%; the middle value is on the limit's open side.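

In this assay compound 4 gives > 22000 nM, a limit and not a number. Its steps from compound 1, compound 2 and compound 3 cannot be read. The compounds shown leave open whether the true values of these four compounds differ at all.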